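Notes on ester variants and metabolic stability

The compounds below may be only part of what the source reports. "The series", "measured", "known", "first", "only" and "open" are said of these compounds alone.

Measured so far:
compound 1 `C[C@@H](O)[C@H]1C(=O)N2C(C(=O)OCOC(=O)OC3CCCCC3)=C(S[C@@H]3CN[C@H](C(=O)Nc4cccc(C(=O)O)c4)C3)[C@H](C)[C@H]12` gives, as a limit of the assay and not a number, > 95% in an ADME assay for metabolic stability, read by LC-MS, with a stated time of 3 h, at pH 6.5, tested at 50 uM; on this read-out higher numbers stand for a more stable compound and lower numbers for a less stable compound.
compound 2 `CC(C)OC(=O)C1=C(S[C@@H]2CN[C@H](C(=O)Nc3cccc(C(=O)OC(C)C)c3)C2)[C@H](C)[C@@H]2[C@@H]([C@@H](C)O)C(=O)N12` gives, likewise only as a limit, > 95% in this assay.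
compound 3 `C[C@@H](O)[C@H]1C(=O)N2C(C(=O)OCOC(=O)OC3CCCCC3)=C(S[C@@H]3CN[C@H](C(=O)Nc4cccc(C(=O)OCOC(=O)OC5CCCCC5)c4)C3)[C@H](C)[C@H]12` gives, again only as a limit, > 95% in this assay.

Compound 1 therefore stands at the upper limit of this assay, and no number is known for it. The same holds for every value shown, because of the limit of > 95% in this assay, at which 3 of the 3 values shown sit. Among the measured compounds shown here, the one single-point change measured in the set, a step that the two limits leave unreadable from compound 1 to compound 3, is for that reason unreadable in size and direction.

Compound 4 `CC(C)OC(=O)OCOC(=O)C1=C(S[C@@H]2CN[C@H](C(=O)Nc3cccc(C(=O)O)c3)C2)[C@H](C)[C@@H]2[C@@H]([C@@H](C)O)C(=O)N12` differs from compound 1 by isopropyl in place of cyclohexyl on an oxygen next to a carbonyl group. For the measured compounds named here, no measured step covers this change: the step from compound 1 to compound 3 concerns a different place and is itself hidden by the limit, and compound 2 is not connected to compound 4 by a single-point step. Since all three shown values sit at the limit (the limit of > 95% in this assay, at which 3 of the 3 values shown sit), the working expectation for compound 4 in this assay is a value at or near that same limit, 95%, within 85% to 100%. The expected step of a number no higher from compound 1 to compound 4 (the limit leaves the size open) is accordingly none beyond the scatter.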

Compound 4, percent of the compound remaining: > 95%
Compound 4 ended at the assay's limit (the forecaster's own chance of this, stated with the estimate: 80%); the middle value lies on the limit itself.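

The step from compound 1 to compound 4, isopropyl in place of cyclohexyl, cannot be read in this assay, because both results are limits and not numbers: the limit of > 95% in this assay, at which 4 of the 4 values shown sit. The compounds shown leave open how far their stability differs and whether either single-place change alters it at all under these conditions.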